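Nitro in place of methoxy: compound 3 to compound 4

A few compounds are considered here, and "the series" means these few. Any claim that something is new, unique, unknown or untested is made for them only; others in the source may bear on it.

In an ADME assay on Vero cells (Chlorocebus sabaeus) for inhibition (a higher number here means that more compound is tolerated, a lower number that less compound is tolerated), compound 1 (`O=C1/C(=C/c2ccccc2Cl)CCC/C1=C\c1ccccc1Cl`) gives 30600 nM, compound 2 (`O=C1/C(=C/c2c(Cl)cccc2Cl)CCC/C1=C\c1c(Cl)cccc1Cl`) gives 574000 nM and compound 3 (`COc1ccc(/C=C2\CCC/C(=C\c3cccc(OC)c3OC)C2=O)cc1`) gives 401000 nM. Compound 3 thus sits level with compound 2, their two values lying within the scatter of each other, while compound 1 stands lower, beyond the scatter.

Compound 4 (`COc1cccc(/C=C2\CCC/C(=C\c3ccc([N+](=O)[O-])cc3)C2=O)c1OC`) carries nitro in place of methoxy on an aromatic carbon, para to a large group, compared with compound 3: nitro in place of methoxy on an aromatic carbon. The same difference reads 4-methoxyphenyl to 4-nitrophenyl. Within the data shown here, no measured pair differs in one place only, so there is no direct precedent for this exchange. Among the measured compounds shown here, the sole guide is the spread of the three values, in which compound 1 at 30600 nM shows that much lower numbers occur. A moderate fall is expected, a 2.7-fold lower number from compound 3 to compound 4 (0.43 log units; beyond the scatter), although the estimate is loose and a result close to the starting value remains possible. For compound 4 the estimated value is 150000 nM, with an expected range of 30000 nM to 500000 nM.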

Compound 4, half-maximal cytotoxic concentration: < 10000 nM
Compound 4 gave a limit, no number; the forecaster's own chance of this, stated with the estimate: 10%; middle value at least 15-fold (1.17 log units) away from the limit.
By their numbers in this assay, from the lowest: compound 1; then compounds 3 and 2 (each within the scatter of the next). At a limit, below all of these: compound 4.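

In this assay compound 4 stands at a limit, < 10000 nM, and not at a number. Nitro in place of methoxy on an aromatic carbon, para to a large group, gives the only single-place step in the series, an at least 40-fold lower number from compound 3 to compound 4 (1.60 log units; beyond the scatter), and its full size stays unknown on one side: the limit of < 10000 nM in this assay, at which 1 of the 4 values shown sits. Among these compounds, the earlier compounds differed in more than one place, so only this step ties a large change in this assay to one position.

On these data alone, whether the fall comes from gaining nitro or from losing methoxy stays open, and a plain hydrogen, an amine or a carboxylic acid at this position would help separate the two. Also open, as far as these compounds go, is whether the same exchange on the other aromatic ring would give a similar step.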